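The source may hold more compounds than are shown below. What is called first, only, known or untested is meant among the compounds shown, and "the series" means these compounds.

Measured so far:
compound 1 `O=C1Nc2ccc(Br)cc2/C1=N/NC(=S)N/N=C/c1ccc(-c2ccccc2)cc1` — 3250 nM
compound 2 `O=C1Nc2ccc(Br)cc2/C1=N/NC(=S)N/N=C/c1c(F)cccc1Cl` — 1610 nM

In a functional assay on HeLa cells (Homo sapiens) for inhibition, read by MTT assay (a higher number here means a weaker inhibitor, a lower number a stronger inhibitor), compound 2 holds the lower of the two numbers; compound 1 gives the higher one, and that gap lies beyond the scatter. Compound 3 `O=C1Nc2ccc(Br)cc2/C1=N/NC(=S)N/N=C/c1c(Cl)cccc1Cl` differs from compound 2 by chloro in place of fluoro on an aromatic carbon. Within the data shown here, no pair of measured compounds shows this change, so nothing anchors its size. The step expected here is a 1.2-fold lower number from compound 2 to compound 3 (0.06 log units; within the scatter), with no direction that should stand clearly beyond the scatter. For compound 3 the estimated value is 1400 nM, in a range from 600 nM to 3500 nM.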

Compound 3, half-maximal inhibitory concentration: 3530 nM
Compound 3: middle estimate off by 2.5-fold (0.40 log units), on the low side; the measured number lies above the stated range.
By their numbers in this assay, from the lowest: compound 2; then compounds 1 and 3 (each within the scatter of the next).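

Among these compounds, replacing fluoro with chloro on this aromatic carbon, turning 2-chloro-6-fluorophenyl into 2,6-dichlorophenyl, gives the first one-place comparison. In this assay, the result is a 2.2-fold higher number from compound 2 to compound 3 (0.34 log units; beyond the scatter), so the fluoro-bearing compound 2 keeps the advantage in this pair, though the step is modest. No available evidence accounts for the step.

The compounds shown leave open how a hydrogen, a methoxy group or an amine at this carbon would compare. Going by these compounds, it also remains open whether the same step would appear with other aryl groups on the shared core.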